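The source may report more compounds than this note shows. Statements on the series, on what has been measured and on what is new or still open speak of the compounds shown alone.

Two compounds in this series carry a measurement, and one more awaits it. Compound 1 `COc1ccc(-n2ccc(=O)c(C(=O)Nc3ccc(Oc4ccnc5c4ccn5C)cc3)n2)cc1` was tested in a functional assay on MCF7 cells (Homo sapiens) for cytotoxicity, read by MTT assay, with a stated time of 72 h; a lower number here means a stronger inhibitor, a higher number a weaker inhibitor. For compound 1 the result is a limit of the assay, > 60000 nM, rather than a number. Compound 2 `Cn1ccc2c(Oc3ccc(NC(=O)c4nn(-c5ccc(Cl)c(F)c5)ccc4=O)cc3)ccnc21` differs from compound 1 by 4-chloro-3-fluorophenyl in place of 4-methoxyphenyl on an aromatic nitrogen, and in this assay compound 2 gives 16800 nM. Compound 2 thus holds the only number shown, the measured step being an at least 3.5-fold lower number from compound 1 to compound 2 (0.55 log units; beyond the scatter); what can be said about that step rests on (the limit of > 60000 nM in this assay, at which 1 of the 2 values shown sits). Compound 3 `Cn1ccc2c(Oc3ccc(NC(=O)c4nn(-c5ccc(Cl)c(C(F)(F)F)c5)ccc4=O)cc3)ccnc21` is not yet measured. It differs from compound 2 by trifluoromethyl in place of fluoro on an aromatic carbon, ortho to a chloro group and meta to a large group. Among the compounds with values here, only the step from compound 1 to compound 2 touches the same ring, and it was at least modest. A change of comparable or smaller size is expected here, so compound 3 is estimated at 10000 nM, between 3000 nM and 40000 nM, an expected step of a 1.7-fold lower number from compound 2 to compound 3 (0.23 log units; within the scatter).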

Compound 3, half-maximal inhibitory concentration: 15200 nM
For compound 3 the middle estimate is 1.5-fold (0.18 log units) below the measured one; the measured number falls inside the stated range.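

In this assay, the aromatic carbon ortho to a chloro group and meta to a large group accepts trifluoromethyl in place of fluoro, a change from 1 heavy atom to 4, with a 1.1-fold lower number from compound 2 to compound 3 (0.04 log units; within the scatter), so at this position the larger group cannot be told apart from fluoro in this assay. The second new comparison, 4-chloro-3-(trifluoromethyl)phenyl in place of 4-methoxyphenyl on an aromatic nitrogen, gives an at least 3.9-fold lower number from compound 1 to compound 3 (0.59 log units; beyond the scatter), which shows that the separation from compound 1 seen with the fluoro ring also holds with the trifluoromethyl ring. The value of compound 1 is a limit and not a number, so the full size of this step stays unknown: the limit of > 60000 nM in this assay, at which 1 of the 3 values shown sits.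

The compounds shown leave open whether a group of another kind at this position, such as an amine, a nitrile or a carboxylic acid, would separate from fluoro and trifluoromethyl. Compound 2 and compound 3 both carry the chloro group, so how much of their separation from compound 1 belongs to that group, and how much to the group ortho to it, remains unresolved.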